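The source may hold more compounds than are shown below. What is called first, only, known or untested is meant among the compounds shown, and "the series" means these compounds.

Among the measured compounds shown here, in a functional assay on MDA-MB-231 cells (Homo sapiens) for cytotoxicity, read by MTT assay, with a stated time of 48 h (on this read-out lower numbers stand for stronger inhibition and higher numbers for weaker inhibition), compound 2 `Cc1ccc(C(=O)/C=C/c2ccc3c(c2)B(O)OC3)cc1` gives 6500 nM, the higher of the two numbers measured so far; compound 1 `O=C(/C=C/c1ccc2c(c1)B(O)OC2)c1ccccc1` gives 2300 nM. Compound 3 `CCc1ccc(C(=O)/C=C/c2ccc3c(c2)B(O)OC3)cc1` differs from compound 2 by methyl in place of hydrogen on a saturated chain carbon bound to an aromatic carbon. For the measured compounds named here, the only measured step that bears on growing this end of the molecule is a 2.8-fold higher number from compound 1 to compound 2 (0.45 log units; beyond the scatter), a weakening beyond the scatter. Extending the same carbon once more is expected to move this assay in the same direction by about a 1.4-fold higher number from compound 2 to compound 3 (0.14 log units; within the scatter), or to stay within the scatter. Compound 3 is therefore estimated at 9000 nM, with a range from 3500 nM to 22000 nM.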

Compound 3, half-maximal inhibitory concentration: 9800 nM
Compound 3: the middle estimate sits 1.1-fold (0.04 log units) below what was measured, within the range that was stated.
By their numbers in this assay, from the lowest: compound 1; then compounds 2 and 3 (each within the scatter of the next).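

In this assay, going from methyl to ethyl gives a 1.5-fold higher number from compound 2 to compound 3 (0.18 log units; within the scatter), so the added carbon on the saturated chain leaves compounds 2 and 3 indistinguishable. The comparison with hydrogen gives a 4.3-fold higher number from compound 1 to compound 3 (0.63 log units; beyond the scatter), so the weakening relative to hydrogen seen with methyl also holds for ethyl. No measurement shown here offers an explanation for these results. As far as these compounds go, whether a longer chain would stay within the scatter of ethyl remains open, as does how an amine or a carboxylic acid in place of hydrogen on that aromatic carbon would read.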